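This account rests on a few compounds, and the source may have more. Where it says the series, first, only, none or still open, it means among the compounds named here.

The shared core of compound 1 `Fc1cc(Cl)ccc1Cn1nnc2c(Br)cccc21` is a fused two-ring system carrying a halogenated benzyl group. In an ADME assay on microsomes from liver (Homo sapiens) for metabolic stability, tested at 2.5 uM (a lower number here means slower removal, a higher number faster removal of the compound), compound 1 gives 0.5 mL/min/g. Compound 2 `Fc1cccc2c1nnn2CC1CC1` has a cyclopropylmethyl group on the same core, with a fluoro on the carbon ring; in this assay compound 2 gives "not determined" (no result reported), so no number anchors it. Compound 3 `FC(F)(F)c1cccc2c1nnn2CC1CC1` differs from compound 2 by trifluoromethyl in place of fluoro on an aromatic carbon. Within the data shown here, no measured pair shows what this change does, so a step within the usual scatter, in either direction, is expected. The value of compound 3 in this assay is estimated at 0.6 mL/min/g, between 0.2 mL/min/g and 2 mL/min/g.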

Compound 3, intrinsic clearance in a liver preparation (reported as CLH), per the amount of preparation that the assay uses: 0.3 mL/min/g
Compound 3: middle estimate off by 2.0-fold (0.30 log units), on the high side; measured number inside the range.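

Among these compounds, compound 2 has no number in this assay, so no step to compound 3 can be read. From the compounds shown here alone, whether trifluoromethyl in place of fluoro speeds or slows removal stays open, and no evidence here bears on the result for compound 3.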